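Aryl variation on the acylurea side of the oxindole series

This account rests on a few compounds, and the source may have more. Where it says the series, first, only, none or still open, it means among the compounds named here.

Compound 2 `CCCCOC(=O)Nc1cccc(NC(=O)NC(=O)N2CCN(C(=O)CN3C(=O)C(=O)c4cc([N+](=O)[O-])ccc43)CC2)c1` gives 87% in an assay on isolated protein for inhibition of Chymotrypsin-C (Homo sapiens), tested at 20 ug/mL (a higher number here means more inhibition at the concentration tested (going by the name of the read-out), a lower number less inhibition), the highest of the three numbers measured but within the scatter of both neighbours. Compound 3 `O=C(NC(=O)N1CCN(C(=O)CN2C(=O)C(=O)c3cc(OC(F)(F)F)ccc32)CC1)Nc1cccc2ccccc12` gives 79% in this assay, and compound 1 `N#Cc1cccc(NC(=O)NC(=O)N2CCN(C(=O)CN3C(=O)C(=O)c4cc(OC(F)(F)F)ccc43)CC2)c1` gives 77%. Going by the values given here, the one measured step on the aryl substituent, a number 2 percentage points higher from compound 1 to compound 3 (within the scatter), shows the number staying level, within the scatter, when the group at this position is exchanged. Compound 4 `CCOC(=O)c1cccc(NC(=O)NC(=O)N2CCN(C(=O)CN3C(=O)C(=O)c4cc([N+](=O)[O-])ccc43)CC2)c1` differs from compound 2 by ethoxycarbonyl in place of (butoxycarbonyl)amino on an aromatic carbon. Since the comparable aryl change in a number 2 percentage points higher from compound 1 to compound 3 (within the scatter) moved nothing beyond the scatter, and all three numbers lie close together, the step of a number 7 percentage points lower from compound 2 to compound 4 (within the scatter) is expected to stay within the scatter. Compound 4 is estimated at 80%, with a range from 65% to 92%.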

Compound 4, a percentage reported as inhibition, at one concentration (the size of the read-out at that concentration, not a potency): 83%
The estimate for compound 4 lay 3 percentage points below the measured number; the range from low to high includes it.
By their numbers in this assay, from the lowest: compounds 1, 3, 4 and 2 (each within the scatter of the next).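

Exchanging (butoxycarbonyl)amino for ethoxycarbonyl on this aromatic carbon gives a number 4 percentage points lower from compound 2 to compound 4 (within the scatter) in this assay, so the number stays level within the scatter. This change removes the hydrogen-bond donor and shortens the group from 8 heavy atoms to 5, and it extends the level picture from the earlier aryl exchange to a pair sharing a nitro group. No available evidence explains this result.

On these data alone, whether a carboxylic acid, a free amine or a longer chain on this carbon would also keep the number level remains open. As far as these compounds go, the same exchange also remains open for compounds carrying trifluoromethoxy.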